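Core aryl replacement in a cytotoxicity series

The compounds below may be only part of what the source reports. "The series", "measured", "known", "first", "only" and "open" are said of these compounds alone.

compound 1 `COc1ccc(F)cc1CNCCCNc1ccnc2cc(Oc3cccc(N(C)C)c3)ccc12`: 3300 nM
compound 2 `COc1cccc(CNCCCNc2ccnc3cc(Oc4cccc(N(C)C)c4)ccc23)c1O`: 7300 nM

Both numbers come from an ADME assay on HepG2 cells (Homo sapiens) for cytotoxicity, read by luminescence, CellTiter-Glo and ATP content, with a stated time of 72 h; a lower number here means that less compound is needed, a higher number that more compound is needed for the effect. Compound 1 stands as the lower of the two; the step of a 2.2-fold higher number from compound 1 to compound 2 (0.34 log units; beyond the scatter) separates it from compound 2, and that step alters only the group on the saturated chain carbon bound to the amine nitrogen. Compound 3 `COc1ccc(F)cc1CNCCCNc1ccnc2cc(-c3ccc(C(F)(F)F)cc3)ccc12` is unmeasured and keeps that side of compound 1 unchanged; its change sits on the core: 4-(trifluoromethyl)phenyl in place of 3-(dimethylamino)phenoxy on an aromatic carbon. No measured step touches this position, so nothing shown speaks to size or direction. For compound 3 the expected value in this assay is 2800 nM, within 800 nM to 9000 nM. The step of a 1.2-fold lower number from compound 1 to compound 3 (0.07 log units; within the scatter) is expected to stay within the scatter, with the range kept wide.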

Compound 3, half-maximal effective concentration: 5190 nM
The estimate for compound 3 lay 1.9-fold (0.27 log units) below the measured number, and the stated range covers the measured number.
By their numbers in this assay, from the lowest: compounds 1, 3 and 2 (each within the scatter of the next, the first and the last beyond it).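

Going by these compounds alone, at this aromatic carbon of the shared core, 4-(trifluoromethyl)phenyl in place of 3-(dimethylamino)phenoxy gives a 1.6-fold higher number from compound 1 to compound 3 (0.20 log units; within the scatter), the first reading at this position. The count of heavy atoms stays the same and hydrogen-bond acceptors go from 2 to 0, with the step still within the scatter. No measurement available bears on the reason for this result.

Open, going by these compounds, is whether this carbon accepts groups without an aromatic ring, such as an amine or a carboxylic acid. Also open, on these data alone, is whether the step holds with the 2-hydroxy-3-methoxyphenyl group of compound 2.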